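The source may hold more compounds than are shown below. What is called first, only, known or untested is meant among the compounds shown, and "the series" means these compounds.

In a functional assay on cells (Cancer cell lines, Homo sapiens) for cytotoxicity, read by sulforhodamine B assay, with a stated time of 48 h (a lower number here means a stronger inhibitor of growth, a higher number a weaker inhibitor of growth), compound 1, `O=C1N=C(N2N=C(c3ccccc3)CC2c2ccccc2O)S/C1=C1/C(=O)Nc2ccccc21`, gives 2410 nM. Its companion compound 2, `O=C1N=C(N2N=C(c3ccccc3)CC2c2ccccc2O)S/C1=C1/C(=O)Nc2ccc(Br)cc21`, gives 280 nM in this assay. Within the data shown here, the one measured step between them is an 8.6-fold lower number from compound 1 to compound 2 (0.93 log units; beyond the scatter), with bromo in place of hydrogen on an aromatic carbon. Compound 1 therefore stands at the highest of the two numbers, and the nearest other compound is compound 2.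

Compound 3, `CN(C)c1ccc(C2CC(c3ccccc3)=NN2C2=NC(=O)/C(=C3\C(=O)Nc4ccccc43)S2)cc1`, changes compound 1 at a different place: 4-(dimethylamino)phenyl in place of 2-hydroxyphenyl on a saturated ring carbon. Among the measured compounds shown here, no measured step touches this saturated ring carbon; the only step known, from compound 1 to compound 2, alters an aromatic carbon elsewhere in the shared core, so it does not tell how this assay answers a swap of the group on the saturated ring carbon. With nothing to lean on, the expectation for compound 3 is a step of a 1.0-fold lower number from compound 1 to compound 3 (0.00 log units; within the scatter) in this assay, that is, no change beyond the scatter, though the range must be wide. Compound 3 is thus estimated at 2400 nM in this assay, within 600 nM to 9000 nM.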

Compound 3, concentration for 50% growth inhibition: 1220 nM
The estimate for compound 3 lay 2.0-fold (0.29 log units) above the measured number; measured number inside the range.
By their numbers in this assay, from the lowest: compound 2; then compounds 3 and 1 (each within the scatter of the next).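

In this assay, among these compounds, this is the first look at the saturated ring carbon, and the swap from 2-hydroxyphenyl to 4-(dimethylamino)phenyl gives a 2.0-fold lower number from compound 1 to compound 3 (0.30 log units; within the scatter). A larger group with 0 hydrogen-bond donors can therefore replace one with 1 hydrogen-bond donor at this position without a change beyond the usual scatter, so in this pair the hydroxy group is not needed to keep growth inhibition in the same range. No measurement available here explains why the two groups are so hard to tell apart in this assay.

Because 2-hydroxyphenyl and 4-(dimethylamino)phenyl differ both in what the phenyl ring carries and in where it carries it, this single pair cannot separate those two changes, and a single swap cannot show how much freedom the position really has. Still open, on these data alone, is whether a plain phenyl, or a phenyl ring carrying a methoxy group or a carboxylic acid, would also stay within the scatter on this carbon, and whether the bromo of compound 2 would bring a similar step when combined with 4-(dimethylamino)phenyl.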